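This account rests on a few compounds, and the source may have more. Where it says the series, first, only, none or still open, it means among the compounds named here.

Measured compounds:
compound 1 `Cc1ccccc1NNC(=O)c1ccc(NS(=O)(=O)c2cnc(O)nc2O)cc1` — 14500 nM
compound 2 `O=C(NNc1ccccc1Cl)c1cccc(NS(=O)(=O)c2cnc(O)nc2O)c1` — 1460 nM

Of the compounds shown here, two have been measured in a functional assay on A549 cells (Homo sapiens) for antiproliferative activity, read by MTT assay, with a stated time of 24 h; on this read-out higher numbers stand for weaker inhibition and lower numbers for stronger inhibition. Compound 1 `Cc1ccccc1NNC(=O)c1ccc(NS(=O)(=O)c2cnc(O)nc2O)cc1` gives 14500 nM, while compound 2 `O=C(NNc1ccccc1Cl)c1cccc(NS(=O)(=O)c2cnc(O)nc2O)c1` gives 1460 nM. Of the two numbers, compound 2 stands lowest, and the gap to compound 1 is beyond the scatter of repeated measurements, so compound 2 is the stronger inhibitor of the pair in this assay. Among the measured compounds shown here, the two differ in more than one place, so no single step between them can be read off.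

Compound 3 `O=C(NNC(=O)c1cccc(NS(=O)(=O)c2cnc(O)nc2O)c1)c1ccc(F)cc1` has not yet been measured. It is built from compound 2 by one change: (4-fluorophenyl)carbonyl in place of 2-chlorophenyl on an amine nitrogen. For the measured compounds named here, no measured pair shows this change or anything close to it, so there is no precedent in these data for its effect. The expectation for compound 3 is therefore anchored on compound 2 at 1460 nM and widened on both sides. A modest weakening is thought somewhat more likely than a gain, but a result within the scatter is also plausible. The step from compound 2 to compound 3 is estimated as a 2.1-fold higher number from compound 2 to compound 3 (0.31 log units; beyond the scatter), and compound 3 is expected to give about 3000 nM in this assay, with a range from 800 nM to 12000 nM.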

Compound 3, half-maximal inhibitory concentration: > 20000 nM
Compound 3 ended at the assay's limit; the forecaster's own chance of this, stated with the estimate: 5%; middle value at least 6.6-fold (0.82 log units) away from the limit.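

Compound 3 gives > 20000 nM in this assay, and this reading is a limit of the assay and not a number: the limit of > 20000 nM in this assay, at which 1 of the 3 values shown sits. The earlier pair differed in more than one place and could say nothing about any single position, whereas (4-fluorophenyl)carbonyl in place of 2-chlorophenyl on an amine nitrogen gives an at least 13-fold higher number from compound 2 to compound 3 (1.13 log units; beyond the scatter) and so shows that this one change is enough to take the series from the activity of compound 2 to the limit of the assay. The position is therefore not a neutral one in this pair, although the step marks only a lower bound on the loss and the change swaps the ring substituent and adds a carbonyl at the same time.

The compounds shown leave open whether the loss goes with the carbonyl or with the move from chlorine to fluorine on the ring, a question that a 4-fluorophenyl directly on the same nitrogen or a (2-chlorophenyl)carbonyl there would separate. They also leave open how a small acetyl group or an unsubstituted phenyl would fare at this nitrogen.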